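Pyridin-3-yl to Pyridin-4-yl: An Expected Small Step

The source may report more compounds than this note shows. Statements on the series, on what has been measured and on what is new or still open speak of the compounds shown alone.

Compound 1, `COc1ccc(C(=O)/C=C/c2cn(-c3ccccc3)nc2-c2ccsc2)c(OC)c1OC`: 5800 nM
Compound 2, `COc1ccc(C(=O)/C=C/c2cn(-c3ccccc3)nc2-c2cccnc2)c(OC)c1OC`: 1100 nM
Compound 3, `COc1ccc(C(=O)/C=C/c2cn(-c3ccccc3)nc2-c2cccnc2)c(OC)c1`: 1300 nM

These three compounds were tested in a functional assay on HCT-116 cells (Homo sapiens) for inhibition, read by sulforhodamine B assay, with a stated time of 72 h; a lower number here means a stronger inhibitor, a higher number a weaker inhibitor. Compound 2 stands lowest of the three numbers; compound 3 sits within the scatter of it, while compound 1 gives a higher number beyond the scatter. Compound 4, `COc1ccc(C(=O)/C=C/c2cn(-c3ccccc3)nc2-c2ccncc2)c(OC)c1OC`, differs from compound 2 in one place: pyridin-4-yl in place of pyridin-3-yl on an aromatic carbon. Among the compounds with values here, no measured step covers this exact exchange. The step of a 5.3-fold lower number from compound 1 to compound 2 (0.72 log units; beyond the scatter) shows that exchanging the ring on the same aromatic carbon can move the number beyond the scatter, while a 1.2-fold higher number from compound 2 to compound 3 (0.07 log units; within the scatter) stayed within it. Lacking a direct precedent, the step expected here, a 1.2-fold higher number from compound 2 to compound 4 (0.07 log units; within the scatter), is one within the scatter. Compound 4 is therefore estimated at 1300 nM, with a range from 500 nM to 3500 nM.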

Compound 4, half-maximal inhibitory concentration: 1300 nM
The estimate for compound 4 equals the measured number at the digits printed; measured number inside the range.
By their numbers in this assay, from the lowest: compounds 2, 3 and 4 (each within the scatter of the next); then compound 1.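

In this assay, the exchange of pyridin-3-yl for pyridin-4-yl gives a 1.2-fold higher number from compound 2 to compound 4 (0.07 log units; within the scatter), so this position does not separate these two rings. The earlier compounds shown here set only pyridin-3-yl against thiophen-3-yl; a 4.5-fold lower number from compound 1 to compound 4 (0.65 log units; beyond the scatter) shows that a second pyridine ring also stands apart from thiophen-3-yl, so the difference is not tied to pyridin-3-yl alone. No evidence is available on what lies behind these numbers. The compounds shown leave open how pyridin-2-yl would read at this position, and whether an amine on the pyridin-4-yl ring would move the number.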